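This account rests on a few compounds, and the source may have more. Where it says the series, first, only, none or still open, it means among the compounds named here.

Measured in a functional assay on HeLa cells (Homo sapiens) for inhibition, read by CCK-8 assay, with a stated time of 48 h; a higher number here means a weaker inhibitor, a lower number a stronger inhibitor:
- compound 1 `O=[N+]([O-])c1ccc(NC(=S)NCCNS(=O)(=O)c2ccc(-c3ccccc3O[C@H]3CC[C@@H](O)CC3)s2)cc1`: > 20000 nM (a limit, not a number)
- compound 2 `O=[N+]([O-])c1ccc(NC(=S)NCCNS(=O)(=O)c2ccc(-c3ccccc3OCc3ccccc3)s2)cc1`: 7100 nM

Within the data shown here, compound 2, at 7100 nM, gives the only actual number so far. Compound 1 gives only a limit of the assay, > 20000 nM.

Next to be measured is compound 3 `O=[N+]([O-])c1ccc(NC(=S)NCCNS(=O)(=O)c2ccc(-c3ccccc3O[C@H]3CC[C@H](O)CC3)s2)cc1`, which has 4-hydroxycyclohexyl in place of benzyl on an oxygen on an aromatic ring. Among the measured compounds shown here, the one measured step that bears on this is the same exchange in the opposite sense, an at least 2.8-fold lower number from compound 1 to compound 2 (0.44 log units; beyond the scatter), with benzyl in place of 4-hydroxycyclohexyl. As that step starts from a limit, it fixes a minimum size and not a full size. It is also a single step, so the range is kept wide.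

In this assay, a higher number beyond the scatter is therefore expected, given an at least 2.8-fold lower number from compound 1 to compound 2 (0.44 log units; beyond the scatter). The expected step is a 2.8-fold higher number from compound 2 to compound 3 (0.45 log units; beyond the scatter). A reading at the limit of the assay would also be unsurprising. For compound 3 the estimated value is 20000 nM, with an expected range of 9000 nM to 45000 nM.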

Compound 3, half-maximal inhibitory concentration: 5400 nM
For compound 3 the middle estimate is 3.7-fold (0.57 log units) above the measured one; measured number below the stated range.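

In this assay, putting 4-hydroxycyclohexyl on the oxygen on the aromatic ring in place of benzyl does not by itself cost activity, as the configuration of compound 3 shows (a 1.3-fold lower number from compound 2 to compound 3 (0.12 log units; within the scatter)). Compound 1 gives > 20000 nM, which is a limit and not a number. The step between the two cyclohexyl compounds (an at least 3.7-fold lower number from compound 1 to compound 3 (0.56 log units; beyond the scatter)) therefore gives a minimum size only, and it can be traced to configuration alone, the first effect of that kind in this series: the fact that compounds 1 and 3 differ only in the configuration as drawn.

As far as these compounds go, it remains open whether the hydroxyl on the cyclohexyl ring contributes at all, a question that an amine or a carboxylic acid in its place, or the plain cyclohexyl group, would address in the configuration of compound 3. Only the group on the oxygen varies among the compounds shown, so it is also unknown whether the preference for one configuration would persist with changes elsewhere on the shared core.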